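Methyl in Place of Cyano on the Benzyl Group

This account rests on a few compounds, and the source may have more. Where it says the series, first, only, none or still open, it means among the compounds named here.

The measured compounds are:
compound 1, `N#Cc1ccccc1Cc1cnc(CCc2ccc(-c3ccccc3C(=O)O)cc2)[nH]1`, 5480 nM
compound 2, `CCCCc1cnc(C(CCC)Cc2ccc(-c3ccccc3C(=O)O)cc2)[nH]1`, 1180 nM
compound 3, `CCCCc1cnc(CCCc2ccc(-c3ccccc3C(=O)O)cc2)[nH]1`, 5600 nM

All three carry the same acid-bearing biaryl tail linked to an imidazole, and all were tested in an in vitro functional assay on cells for agonist activity at Bombesin receptor subtype-3 (Homo sapiens), read by luminescence and calcium flux; a lower number here means that less compound is needed, a higher number that more compound is needed for the effect. Compound 1 gives 5480 nM in this assay, and compound 3 gives 5600 nM, a number that lies within the scatter of compound 1. Compound 2 gives 1180 nM, a lower number than compound 1 by more than the scatter. Compound 1 therefore has the second highest number of the three, close to compound 3 and well apart from compound 2.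

Compound 4, `Cc1ccccc1Cc1cnc(CCc2ccc(-c3ccccc3C(=O)O)cc2)[nH]1`, differs from compound 1 in one place: methyl in place of cyano on an aromatic carbon. For the measured compounds named here, no pair among the measured compounds shows this change, so there is no step to lean on. The step of a 1.4-fold lower number from compound 1 to compound 4 (0.14 log units; within the scatter) is expected to be modest, with the number for compound 4 expected somewhat lower but not clearly beyond the scatter. Compound 4 is estimated at 4000 nM, in a range from 1500 nM to 12000 nM.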

Compound 4, half-maximal effective concentration: 127 nM
Compound 4: the middle estimate sits 31-fold (1.50 log units) above what was measured, outside the stated range (below it).
By their numbers in this assay, from the lowest: compound 4; then compound 2; then compounds 1 and 3 (each within the scatter of the next).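

In this assay, exchanging cyano for methyl at this aromatic carbon, ortho to a large group, gives a 43-fold lower number from compound 1 to compound 4 (1.63 log units; beyond the scatter). The earlier compounds shown here formed no pair differing in one place, so they could not show that the number is so sensitive to the group held here, and that going from 2-cyanobenzyl to 2-methylbenzyl moves it well beyond the scatter. No measurement shown here bears on the reason for this step.

Going by these compounds, what remains open is whether the step follows from the methyl entering or from the cyano leaving, a question that a chlorine atom, a methoxy group, an ethyl group or a plain hydrogen at this carbon could help to settle. On these data alone, it is also open whether 2-methylbenzyl would have the same effect alongside the branched chain of compound 2.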